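Cytotoxicity Readings Sitting at the Assay Limit

The compounds below may be only part of what the source reports. "The series", "measured", "known", "first", "only" and "open" are said of these compounds alone.

Compound 1 `CCc1ccc(CNC(=O)c2nc3ccc(F)c(OCCc4ccc(C(=O)O)cc4)c3c(=O)[nH]2)cc1`: > 20000 nM
Compound 2 `CCc1cccc(C(C)NC(=O)c2nc3ccc(F)c(OCCc4ccc(C(=O)O)cc4)c3c(=O)[nH]2)c1`: > 20000 nM
Compound 3 `CCc1ccc(CNC(=O)c2nc3cccc(COCc4ccc(C(=O)O)cc4)c3c(=O)[nH]2)cc1`: > 20000 nM

In an ADME assay on HEK293 cells (Homo sapiens) for cytotoxicity, read by resazurin assay, with a stated time of 72 h (on this read-out higher numbers stand for lower toxicity in this test and lower numbers for higher toxicity in this test), compound 1 gives > 20000 nM, which is a limit of the assay and not a number. Compound 2 likewise reaches only the limit > 20000 nM. The change between them, (1-(3-ethylphenyl)ethyl in place of 4-ethylbenzyl on an amide-type nitrogen), therefore gives a step that the two limits leave unreadable from compound 1 to compound 2. Compound 3 also returns the limit > 20000 nM; how its core differs from that of compound 1 is not broken down here. Compound 4 `CCc1cccc(C(C)NC(=O)c2nc3cccc(COCc4ccc(C(=O)O)cc4)c3c(=O)[nH]2)c1` carries the same change, (1-(3-ethylphenyl)ethyl in place of 4-ethylbenzyl on an amide-type nitrogen), on the core of compound 3. Because (the limit of > 20000 nM in this assay, at which 3 of the 3 values shown sit), the step from compound 3 to compound 4 is expected to stay unreadable as well, a step that the limit leaves unreadable from compound 3 to compound 4. Compound 4 is accordingly estimated at 30000 nM in this assay, with an expected range from 15000 nM to 80000 nM.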

Compound 4, half-maximal cytotoxic concentration: > 20000 nM
Compound 4 was reported as a limit (the forecaster's own chance of this, stated with the estimate: 85%); the middle value lies beyond the limit too.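

Compound 3 and compound 4 both give only a limit, so no step can be read between them, nor between compound 1 and compound 2: the limit of > 20000 nM in this assay, at which 4 of the 4 values shown sit. The compounds shown leave open their actual values and whether the amide nitrogen change shifts them.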